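Fluoro for hydrogen on the aminobenzothiazole side of compound 1

This account rests on a few compounds, and the source may have more. Where it says the series, first, only, none or still open, it means among the compounds named here.

Going by the values given here, compound 1 `O=c1cc(-c2ccccc2)oc2cc(OCCCCNc3nc4ccccc4s3)cc(O)c12` gives 4.75 ug/mL in a functional assay on HeLa cells (Homo sapiens) for cytotoxicity, read by sulforhodamine B assay, with a stated time of 48 h (on this read-out higher numbers stand for weaker inhibition and lower numbers for stronger inhibition), the lower of the two numbers measured so far. Compound 2 `Cc1ccc2nc(NCCCCOc3cc(O)c4c(=O)cc(-c5ccccc5)oc4c3)sc2c1` gives 6.56 ug/mL in this assay; the step of a 1.4-fold higher number from compound 1 to compound 2 (0.14 log units; within the scatter) lies within the scatter, so no order between the two is claimed. Compound 3 `O=c1cc(-c2ccccc2)oc2cc(OCCCCNc3nc4ccc(F)cc4s3)cc(O)c12` differs from compound 1 by fluoro in place of hydrogen on an aromatic carbon, turning the (1,3-benzothiazol-2-yl)amino part into (6-fluoro-1,3-benzothiazol-2-yl)amino. Among the compounds with values here, the only measured step that bears on this is a 1.4-fold higher number from compound 1 to compound 2 (0.14 log units; within the scatter), a small substituent entering on an aromatic carbon of the same part of the molecule, and it stayed within the scatter. On that basis the expected step is a 1.0-fold higher number from compound 1 to compound 3 (0.01 log units; within the scatter), that is, none beyond the scatter in this assay. Compound 3 is therefore expected to give 4.9 ug/mL in this assay, within a range from 2.4 ug/mL to 10 ug/mL.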

Compound 3, half-maximal inhibitory concentration: 5.03 ug/mL
Compound 3: the middle estimate sits 1.0-fold (0.01 log units) below what was measured; the measured number falls inside the stated range.
By their numbers in this assay, from the lowest: compounds 1, 3 and 2 (each within the scatter of the next).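

In this assay, fluoro on this aromatic carbon of the six-membered ring gives a step that stays within the scatter (a 1.1-fold higher number from compound 1 to compound 3 (0.02 log units; within the scatter)). Fluoro in place of methyl on that carbon also stays within the scatter (a 1.3-fold lower number from compound 2 to compound 3 (0.12 log units; within the scatter)), so this assay does not separate hydrogen, methyl and fluoro there, and with fluoro a second substituent now joins methyl in leaving the number unresolved from that of compound 1. Nothing at hand explains why these three compounds cannot be told apart.

Open, on these data alone, is whether a methoxy group, an amine or a carboxylic acid on this carbon would move the number beyond the scatter. Also open, as far as these compounds go, is whether fluoro on another carbon of this ring, or a longer chain between the two halves of the molecule, would do so.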